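Swapping methyl for chloro in a cytotoxicity series

The source may hold more compounds than are shown below. What is called first, only, known or untested is meant among the compounds shown, and "the series" means these compounds.

Compound 1 `Cc1ccc(-c2csc(NC(=O)COc3ccccc3C)n2)cc1`: 51700 nM
Compound 2 `Cc1ccccc1OCC(=O)Nc1nc(-c2ccc(Cl)cc2)cs1`: 52100 nM
Compound 3 `Cc1ccc(OCC(=O)Nc2nc(-c3ccc(C)cc3)cs2)cc1`: 37100 nM

All three numbers come from a functional assay on MDA-MB-468 cells (Homo sapiens) for cytotoxicity, read by trypan blue exclusion, with a stated time of 48 h; a higher number here means a weaker inhibitor, a lower number a stronger inhibitor. Compound 2 differs from compound 1 by chloro in place of methyl on an aromatic carbon, and that step is a 1.0-fold higher number from compound 1 to compound 2 (0.00 log units; within the scatter). Compound 3 differs from compound 1 by 4-methylphenyl in place of 2-methylphenyl on an oxygen on a saturated carbon, with a step of a 1.4-fold lower number from compound 1 to compound 3 (0.14 log units; within the scatter). Compound 4 `Cc1ccc(-c2csc(NC(=O)COc3ccc(Cl)cc3)n2)cc1` has not yet been measured in this assay. It differs from compound 3 by chloro in place of methyl on an aromatic carbon, which is the same change that leads from compound 1 to compound 2, made at the same place. Because a 1.0-fold higher number from compound 1 to compound 2 (0.00 log units; within the scatter) stayed within the scatter, the step from compound 3 to compound 4 is expected to be small as well, a 1.0-fold higher number from compound 3 to compound 4 (0.01 log units; within the scatter). Compound 4 is therefore estimated at 38000 nM in this assay, with a likely range from 19000 nM to 76000 nM.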

Compound 4, half-maximal inhibitory concentration: 44700 nM
For compound 4 the middle estimate is 1.2-fold (0.07 log units) below the measured one, within the range that was stated.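

Chloro in place of methyl is a 1.2-fold higher number from compound 3 to compound 4 (0.08 log units; within the scatter) in this assay, and 4-chlorophenyl in place of 2-methylphenyl on the oxygen is a 1.2-fold lower number from compound 1 to compound 4 (0.06 log units; within the scatter). The chloro-for-methyl swap therefore stays small on both cores, and the two steps agree: the same change on two cores in this assay, a 1.0-fold higher number (0.00 log units; within the scatter) from compound 1 to compound 2 and a 1.2-fold higher number (0.08 log units; within the scatter) from compound 3 to compound 4, 1.2-fold (0.08 log units) apart, within the scatter of two such steps

This shows that the swap carried over between these two cores, but only as a change too small to separate from the scatter; it does not show that the swap would stay small on any other core.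

The compounds shown leave open what an amine, a carboxylic acid or a longer chain would do in place of the methyl. They also leave open whether any such group would move the number beyond the scatter.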